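A few compounds are considered here, and "the series" means these few. Any claim that something is new, unique, unknown or untested is made for them only; others in the source may bear on it.

Compound 1 `CCN(CC)c1ccc(C(=O)N2CCCCc3ccccc32)c(Cl)c1`: 19 nM
Compound 2 `O=C(c1ccc(-n2cccc2)cc1)N1CCCCc2ccccc21`: 320 nM

Within the data shown here, in an assay on HeLa cells for binding affinity to Vasopressin V2 receptor (Homo sapiens) (on this read-out lower numbers stand for stronger inhibition and higher numbers for weaker inhibition), compound 2 gives 320 nM, the higher of the two numbers measured so far; compound 1 gives 19 nM. Among the measured compounds shown here, no single-point step links these two, so the gap only shows what the two values are. Compound 3 `O=C(c1ccc(N2CCCC2)cc1)N1CCCCc2ccccc21` differs from compound 2 in one place: pyrrolidin-1-yl in place of 1H-pyrrol-1-yl on an aromatic carbon. For the measured compounds named here, no measured pair carries this change. A somewhat lower number is expected, because compound 1 with its diethylamino group gives 19 nM. The estimated step is a 2.7-fold lower number from compound 2 to compound 3 (0.43 log units; beyond the scatter). Compound 3 is expected to give 120 nM in this assay, with a range of 40 nM to 400 nM.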

Compound 3, half-maximal inhibitory concentration: 1000 nM
Beside the measured number, compound 3's estimate is 8.3-fold (0.92 log units) below it, outside the stated range (above it).
By their numbers in this assay, from the lowest: compound 1; then compound 2; then compound 3.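

In this assay, pyrrolidin-1-yl in place of 1H-pyrrol-1-yl, on an aromatic carbon para to a large group, gives a 3.1-fold higher number from compound 2 to compound 3 (0.49 log units; beyond the scatter) and this step is modest. The two groups match in heavy atoms, donors and acceptors, so what differs in this pair is a non-aromatic ring in place of an aromatic one, and at this position that difference alone moves the number upward. Nothing at hand accounts for this step.

Open, going by these compounds, is whether a morpholin-4-yl ring or an open-chain dimethylamino group at this position would sit nearer compound 2 or compound 3. The compounds shown also do not separate the chloro group of compound 1 from its diethylamino group.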